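The source may hold more compounds than are shown below. What is called first, only, known or untested is meant among the compounds shown, and "the series" means these compounds.

Three compounds that share one core and differ only in the group on a carbon with a double bond to nitrogen have been measured. In a functional assay on A549 cells (Homo sapiens) for cytotoxicity, read by MTT assay, with a stated time of 72 h (a lower number here means a stronger inhibitor, a higher number a weaker inhibitor), compound 1 `O=C(N/N=C/c1ccc(F)cc1)Nc1cc2c(Nc3ccc(F)c(Cl)c3)ncnc2cc1O[C@H]1CCOC1` gives 35100 nM and compound 2 `O=C(N/N=C/c1cccc(Cl)c1Cl)Nc1cc2c(Nc3ccc(F)c(Cl)c3)ncnc2cc1O[C@H]1CCOC1` gives 25000 nM in the same test. The gap between them is a 1.4-fold lower number from compound 1 to compound 2 (0.15 log units; within the scatter) and gives them no order. Compound 3 `O=C(N/N=C/c1ccc(O)c(Br)c1)Nc1cc2c(Nc3ccc(F)c(Cl)c3)ncnc2cc1O[C@H]1CCOC1` stands lowest of the three at 4310 nM in this assay and sits clear of both others. The steps reaching it are an 8.1-fold lower number from compound 1 to compound 3 (0.91 log units; beyond the scatter) and a 5.8-fold lower number from compound 2 to compound 3 (0.76 log units; beyond the scatter) and both are modest.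

Compound 4 `O=C(N/N=C/c1ccc(O)cc1O)Nc1cc2c(Nc3ccc(F)c(Cl)c3)ncnc2cc1O[C@H]1CCOC1` has not yet been measured. It differs from compound 3 in one place: 2,4-dihydroxyphenyl in place of 3-bromo-4-hydroxyphenyl on a carbon with a double bond to nitrogen and the shared core stays the same. Among the measured compounds shown here, no measured step removes the bromine alone or adds a second hydroxy group, so the data offer no direct comparison. The two steps to compound 3 are the nearest guide, and they suggest that compound 3 may be hard to improve on with this change. The step expected here is a 2.3-fold higher number from compound 3 to compound 4 (0.37 log units; beyond the scatter) as an uncertain estimate, a partial move back toward the two weaker compounds. In this assay the estimate for compound 4 is 10000 nM with an expected range from 2500 nM to 30000 nM at the upper end.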

Compound 4, half-maximal inhibitory concentration: 9360 nM
Compound 4: middle estimate off by 1.1-fold (0.03 log units), on the high side; the measured number falls inside the stated range.
By their numbers in this assay, from the lowest: compound 3; then compound 4; then compounds 2 and 1 (each within the scatter of the next).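

In this assay, the step of a 3.8-fold lower number from compound 1 to compound 4 (0.57 log units; beyond the scatter) and the step of a 2.7-fold lower number from compound 2 to compound 4 (0.43 log units; beyond the scatter) show that the lower numbers at this position do not depend on bromine, since the 2,4-dihydroxyphenyl group also separates from both the 4-fluorophenyl and 2,3-dichlorophenyl groups. Among the four compounds, the two groups carrying a hydroxy group give the lower numbers, with no compound going against this, yet the step of a 2.2-fold higher number from compound 3 to compound 4 (0.34 log units; beyond the scatter) shows that the two hydroxy-bearing groups are not equivalent and that the 3-bromo-4-hydroxyphenyl group remains ahead. No available evidence bears on what lies behind these differences.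

Compounds 3 and 4 differ in both the bromine and the second hydroxy group, so the shown compounds leave open how much of the step belongs to each, a question that a plain 4-hydroxyphenyl group would help to settle. Also open, from the compounds shown here alone, is whether a methoxy group or an amine in place of a hydroxy group on this ring would keep the numbers near those of compound 3 or return them toward those of compounds 1 and 2.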